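Shrinking the Ring on a Chemokine Receptor Sulfonamide

The source may hold more compounds than are shown below. What is called first, only, known or untested is meant among the compounds shown, and "the series" means these compounds.

For the measured compounds named here, compound 1 `COCC(=O)N1CCC(NS(=O)(=O)c2ccc(NC(=O)c3ccccc3C)c3ccccc23)CC1` is one of three compounds measured in an assay on L1.2 cells for binding affinity to C-C chemokine receptor type 8 (Homo sapiens); on this read-out higher numbers stand for weaker inhibition and lower numbers for stronger inhibition. In this assay compound 1 gives 15.8 nM, the second highest of the three numbers. Compound 2 `Cc1ccccc1C(=O)Nc1ccc(S(=O)(=O)NC2CCN(C(=O)N3CCCC3)CC2)c2ccccc12` gives 1.1 nM, and compound 3 `CCN(CC)CCCC(=O)N1CCC(NS(=O)(=O)c2ccc(NC(=O)c3ccccc3C)c3ccccc23)CC1` gives 567 nM. Both differ from compound 1 only at the carbonyl carbon: a 14-fold lower number from compound 1 to compound 2 (1.16 log units; beyond the scatter), while a 36-fold higher number from compound 1 to compound 3 (1.55 log units; beyond the scatter). Compound 4 `CCCC(=O)N1CCC(NS(=O)(=O)c2ccc(NC(=O)c3ccccc3C)c3ccccc23)C1` is not yet measured; (1-(propylcarbonyl)pyrrolidin-3-yl in place of 1-((methoxymethyl)carbonyl)piperidin-4-yl on a sulfonamide nitrogen). The two measured steps show that what sits at that carbonyl can move the number a long way in either direction, yet neither step alters the ring itself, so no direction is supported, and the expectation is a number close to that of compound 1 with wide uncertainty. Compound 4 is therefore estimated at 30 nM, with a range from 5 nM to 200 nM, which would mean a 1.9-fold higher number from compound 1 to compound 4 (0.28 log units; within the scatter).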

Compound 4, inhibition constant: 34.3 nM
Beside the measured number, compound 4's estimate is 1.1-fold (0.06 log units) below it; low and high end bracket the measured number.
By their numbers in this assay, from the lowest: compound 2; then compound 1; then compound 4; then compound 3.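

In this assay, for the compounds shown here, the swap on the sulfonamide nitrogen gives a 2.2-fold higher number from compound 1 to compound 4 (0.34 log units; beyond the scatter) and is the first step here that alters the ring itself, taking it from six-membered to five-membered. The group on the carbonyl changes in the same step, so the two changes together shift the number only modestly. No evidence at hand explains this shift.

On these data alone, how much of the step belongs to the ring and how much to the propylcarbonyl group stays open. So does the effect of a longer chain, such as butylcarbonyl, on the five-membered ring.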